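From a 3-bromobenzyl to a 4-cyanobenzyl group

The source may report more compounds than this note shows. Statements on the series, on what has been measured and on what is new or still open speak of the compounds shown alone.

Of the compounds shown here, three built on a shared core have been tested in a functional assay on HL-60 cells (Homo sapiens), read by calcium flux; on this read-out lower numbers stand for an effect already at smaller amounts and higher numbers for an effect only at larger amounts of compound. Compound 1 `COc1cccc(Cc2cc(-c3ccccc3)nn(CC(=O)Nc3ccc(Br)cc3)c2=O)c1` gives only a limit of the assay, > 50000 nM. Compound 2 `COc1cccc(Cc2cc(-c3cccs3)nn(CC(=O)Nc3ccc(F)cc3)c2=O)c1` likewise gives only a limit, > 50000 nM. Compound 3 `Cc1cc(Cc2cccc(Br)c2)c(=O)n(CC(=O)Nc2ccc(Br)cc2)n1` also reaches only a limit, > 50000 nM. Among the measured compounds shown here, compound 3 therefore stands where all three measured compounds stand, at the limit of > 50000 nM in this assay, at which 3 of the 3 values shown sit, and no step between measured compounds can be read from these numbers.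

Compound 4 `Cc1cc(Cc2ccc(C#N)cc2)c(=O)n(CC(=O)Nc2ccc(Br)cc2)n1` is the next compound to be measured in this assay. It differs from compound 3 in one place: 4-cyanophenyl in place of 3-bromophenyl on a saturated chain carbon bound to an aromatic carbon. The 3-bromobenzyl group of compound 3 becomes a 4-cyanobenzyl group in compound 4, and the rest of the structure is kept.

Every measured value sits at the limit of > 50000 nM in this assay, at which 3 of the 3 values shown sit, so the numbers give no direction for this change. The step from compound 3 to compound 4 is expected to show no change beyond the scatter, and a limit is likely to be reported again. Compound 4 is expected to give about 50000 nM in this assay, with a range from 10000 nM to 200000 nM, and the step of a number no higher from compound 3 to compound 4 (the limit leaves the size open) expresses this expectation.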

Compound 4, half-maximal effective concentration: > 50000 nM
Compound 4: a limit, no number; the forecaster's own chance of this, stated with the estimate: 80%; the middle value lies on the limit itself.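

Compound 4 in this assay gives > 50000 nM as a limit of the assay, not a number. Among the compounds shown here, compound 3 and compound 4 both sit at a limit, so no step between them can be read. The compounds shown leave open which change, if any, would bring a readable value in this assay at all, as every value stands at one limit: the limit of > 50000 nM in this assay, at which 4 of the 4 values shown sit.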